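A few compounds are considered here, and "the series" means these few. Any claim that something is new, unique, unknown or untested is made for them only; others in the source may bear on it.

Compound 1, `CC(C)C(=O)OCCc1c(-c2ccccc2Cl)c2cc(Cl)ccc2[nH]c1=O`, gives 62000 nM in an ADME assay on HepG2 2.2.15 cells (Homo sapiens) for cytotoxicity; a lower number here means that less compound is tolerated, a higher number that more compound is tolerated. Among the three measured compounds it holds the second highest number; nearest to it stands compound 2, `COCC(=O)OCCc1c(-c2ccccc2Cl)c2cc(Cl)ccc2[nH]c1=O`, which gives 74000 nM, the step between them being a 1.2-fold higher number from compound 1 to compound 2 (0.08 log units; within the scatter). Compound 3, `O=C(OCCc1c(-c2ccccc2Cl)c2cc(Cl)ccc2[nH]c1=O)C1CCCC1`, gives 46000 nM, reached from compound 1 through a 1.3-fold lower number from compound 1 to compound 3 (0.13 log units; within the scatter). Between the other two, the step is a 1.6-fold lower number from compound 2 to compound 3 (0.21 log units; within the scatter). Compound 4, `O=C(OCCc1c(-c2ccccc2Cl)c2cc(Cl)ccc2[nH]c1=O)c1cccnc1`, has not yet been measured; it differs from compound 1 as follows: pyridin-3-yl in place of isopropyl on a carbonyl carbon. The three measured steps all exchange a group on the same carbonyl carbon, and none of them moves beyond the scatter; none of them, however, brings in an aromatic ring of the kind entering here, so they bear on the new step only loosely. The chemist therefore expects the step of a 1.2-fold lower number from compound 1 to compound 4 (0.09 log units; within the scatter) to remain within the scatter. Compound 4 is estimated at 50000 nM, with a range from 25000 nM to 100000 nM.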

Compound 4, half-maximal cytotoxic concentration: 170000 nM
For compound 4 the middle estimate is 3.4-fold (0.53 log units) below the measured one, outside the stated range (above it).
By their numbers in this assay, from the lowest: compounds 3, 1 and 2 (each within the scatter of the next); then compound 4.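

In this assay, among the compounds shown here, the exchanges among isopropyl, methoxymethyl and cyclopentyl on this carbonyl carbon stayed within the scatter, but pyridin-3-yl gives the first steps beyond it: a 2.7-fold higher number from compound 1 to compound 4 (0.44 log units; beyond the scatter) and a 2.3-fold higher number from compound 2 to compound 4 (0.36 log units; beyond the scatter) and a 3.7-fold higher number from compound 3 to compound 4 (0.57 log units; beyond the scatter) all point the same way. This place therefore does respond to the group it carries, and compound 4 stands apart from the other three compounds, which remain within the scatter of one another. Nothing available explains this shift, so the result stays an observation without a known cause.

The compounds shown leave open whether the aromatic ring itself or its nitrogen goes with the higher number, a question that a phenyl group on the same carbonyl carbon would address. Going by these compounds, how pyridin-2-yl or pyridin-4-yl would compare with pyridin-3-yl also remains open.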